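Sulfonyl aryl trimming in the indazole piperidine series

The source may report more compounds than this note shows. Statements on the series, on what has been measured and on what is new or still open speak of the compounds shown alone.

Going by the values given here, compound 2 `Cc1cccc(S(=O)(=O)c2ccc3[nH]nc(C4CCN(C)CC4)c3c2)c1` gives 50 nM in an assay on HeLa cells for displacement of a labelled ligand from 5-hydroxytryptamine receptor 6 (Homo sapiens) (a higher number here means a weaker inhibitor, a lower number a stronger inhibitor), the highest of the three numbers measured so far. Compound 1 `CC(C)c1ccc(S(=O)(=O)c2ccc3[nH]nc(C4CCN(C)CC4)c3c2)cc1` gives 14 nM and compound 3 `CN1CCC(c2n[nH]c3ccc(S(=O)(=O)c4ccc5ccccc5c4)cc23)CC1` gives 9.6 nM, both beyond the scatter below compound 2. Among the compounds with values here, the only single-point step on the aryl attached to the sulfonyl sulfur is a 3.6-fold higher number from compound 1 to compound 2 (0.55 log units; beyond the scatter), 3-methylphenyl in place of 4-isopropylphenyl.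

Compound 4 `CN1CCC(c2n[nH]c3ccc(S(=O)(=O)c4ccccc4)cc23)CC1` differs from compound 2 by hydrogen in place of methyl on an aromatic carbon; cut one bond further out, 3-methylphenyl goes to phenyl. Within the data shown here, no measured step removes this methyl, so the expectation rests on the region only: the one change on this aryl that was measured, a 3.6-fold higher number from compound 1 to compound 2 (0.55 log units; beyond the scatter), moved the number upward, and the removal of the remaining methyl is a further change on the same ring in the same direction of shrinkage. The expected step from compound 2 to compound 4 is therefore a modest rise, a 1.8-fold higher number from compound 2 to compound 4 (0.26 log units; within the scatter), with wide uncertainty since a flat result within the scatter cannot be excluded.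

For compound 4 in this assay the estimate is 90 nM, with a range from 35 nM to 250 nM.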

Compound 4, inhibition constant: 55 nM
For compound 4 the middle estimate is 1.6-fold (0.21 log units) above the measured one; the measured number falls inside the stated range.
By their numbers in this assay, from the lowest: compounds 3 and 1 (each within the scatter of the next); then compounds 2 and 4 (each within the scatter of the next).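

In this assay, hydrogen in place of the methyl meta to a large group gives a 1.1-fold higher number from compound 2 to compound 4 (0.04 log units; within the scatter), which lies within the scatter, so at this position the methyl cannot be told apart from hydrogen. The step that matters on this aryl is the one from the isopropyl: hydrogen in its place gives a 3.9-fold higher number from compound 1 to compound 4 (0.59 log units; beyond the scatter), beyond the scatter, and compound 2 and compound 4 therefore stand together on the weaker side of compound 1, with 3-methylphenyl reading the same as phenyl. Nothing available here explains either step.

The aryl comparison with compound 1 still mixes the identity of the group with its place on the ring, as 4-isopropylphenyl and 3-methylphenyl differ in both, and the compounds shown do not separate the two, which a 4-methylphenyl or a 3-isopropylphenyl analogue would do. As far as these compounds go, it also remains open whether a group of another kind on this ring, such as a methoxy group, a chlorine atom or an amine, would read like the isopropyl or like hydrogen.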